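Acetyl for methoxy on the shared urea core

The source may hold more compounds than are shown below. What is called first, only, known or untested is meant among the compounds shown, and "the series" means these compounds.

The measured compounds:
compound 1, `CCOC(=O)c1cccc(NC(=O)N[C@@H](C)c2ccccc2)c1`, 100%
compound 2, `COc1cccc(NC(=O)N[C@@H](C)c2ccccc2)c1`, 101%

Compound 2 sits at the top of the two numbers measured in an ADME assay on the whole organism with Oryza sativa as the target, tested at 0.1 uM (a lower number here means a stronger effect, a higher number a weaker effect of the compound at the concentration tested), but only just: its nearest neighbour is compound 1, and the step of a number 1 percentage points higher from compound 1 to compound 2 (within the scatter) is within the scatter, so the two compounds cannot be told apart on these numbers. Compound 3, `CC(=O)c1cccc(NC(=O)N[C@@H](C)c2ccccc2)c1`, is still to be measured. It differs from compound 2 in one place: acetyl in place of methoxy on an aromatic carbon. Going by the values given here, the only measured step that bears on this exchange is the one from compound 1 to compound 2, which also swaps one substituent for another at this aromatic carbon and was a number 1 percentage points higher from compound 1 to compound 2 (within the scatter), that is, within the scatter. Among the compounds with values here, with no measured step at this position having moved the read-out, compound 3 is expected to show no step beyond the scatter, an expected change of a number 1 percentage points lower from compound 2 to compound 3 (within the scatter). Compound 3 is therefore estimated at 100%, with a range from 88% to 112%.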

Compound 3, a percentage reported as activity, at one concentration (the size of the read-out at that concentration, not a potency): 96%
For compound 3 the middle estimate is 4 percentage points above the measured one, within the range that was stated.
By their numbers in this assay, from the lowest: compounds 3, 1 and 2 (each within the scatter of the next).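

In this assay, acetyl in place of methoxy on the aromatic carbon gives a number 5 percentage points lower from compound 2 to compound 3 (within the scatter), and methyl in place of ethoxy on the carbonyl carbon gives a number 4 percentage points lower from compound 1 to compound 3 (within the scatter). This aromatic carbon, meta to a large group, has now carried three different substituents, and compound 1, compound 2 and compound 3 cannot be told apart on this read-out, so the earlier single step is no longer an isolated case. The new comparison also shows that an exchange made on the carbonyl carbon alone, with the carbonyl kept in place, stays within the scatter just as the exchanges of whole substituents do, while nothing available accounts for why these substituents give such similar numbers.

On these data alone, whether an amine or a carboxylic acid on this aromatic carbon, or a longer chain on the carbonyl carbon, would produce a step beyond the scatter remains open. As far as these compounds go, it is also open whether methoxy, acetyl and ethoxycarbonyl would remain indistinguishable if placed elsewhere on the shared core.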